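Stereoisomer pair in the antiproliferative series

This account rests on a few compounds, and the source may have more. Where it says the series, first, only, none or still open, it means among the compounds named here.

In a functional assay on CWR22R cells (Homo sapiens) for antiproliferative activity, read by CCK-8 assay, with a stated time of 5 days (a higher number here means a weaker inhibitor, a lower number a stronger inhibitor), compound 1 (`COc1ccc(CCc2nc3cc(-c4c(C)noc4C)ccc3n2[C@H]2CC[C@H](O)CC2)cc1Cl`) gives 6830 nM as its reading. In this assay compound 2 (`COc1ccc(N2C(=O)C[C@H]2c2nc3cc(-c4c(C)noc4C)ccc3n2[C@H]2CC[C@H](OC)CC2)cc1Cl`) gives 3740 nM as its reading, within the scatter of compound 1. Compound 3 (`COc1ccc(N2C(=O)C[C@@H]2c2nc3cc(-c4c(C)noc4C)ccc3n2[C@H]2CC[C@H](OC)CC2)cc1Cl`) has the same atoms and bonds as compound 2 and differs only in configuration as drawn: the two compounds have the same atoms and bonds and differ only in configuration as drawn: 2 of 3 stereo elements differ; a stereocentre at a saturated ring carbon is drawn S in compound 2 and R in compound 3; a stereocentre at a saturated ring carbon is drawn S in compound 2 and R in compound 3 is the whole change. Within the data shown here, no measured pair shows what such a change does in this assay so no direction is favoured. As far as these compounds go, the expected step (a 1.2-fold lower number from compound 2 to compound 3 (0.10 log units; within the scatter)) is none beyond the scatter, though a large move either way remains open. For compound 3 the estimated value is 3000 nM within a wide expected range (500 nM to 15000 nM).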

Compound 3, half-maximal inhibitory concentration: 3680 nM
Estimate against measurement, compound 3: 1.2-fold (0.09 log units) below, within the range that was stated.
By their numbers in this assay, from the lowest: compounds 3, 2 and 1 (each within the scatter of the next).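

In this assay, among these compounds, the first comparison of configuration alone gives a 1.0-fold lower number from compound 2 to compound 3 (0.01 log units; within the scatter). Both drawn stereocentres change together, and this read-out does not separate the two forms. No other feature enters this comparison: the fact that compounds 2 and 3 differ only in the configuration as drawn.

The contribution of each stereocentre alone remains unresolved, since a compound changed at only one of them is not among those shown. Also open, as far as these compounds go, is whether the two configurations would still read alike with an amine or a carboxylic acid in place of a methoxy group.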